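Ethoxycarbonyl to carbamoyl: expected cytotoxicity of compound 4

A few compounds are considered here, and "the series" means these few. Any claim that something is new, unique, unknown or untested is made for them only; others in the source may bear on it.

Measured compounds:
compound 1, `CCOC(=O)c1c(N/N=C2/C(=O)NN=C2N)sc2c1CCCC2`: 60%
compound 2, `CC1=NNC(=O)/C1=N/Nc1sc2c(c1C#N)CCCC2`: 29.8%
compound 3, `CCOC(=O)c1c(N/N=C2/C(=O)NN=C2C)sc2c1CCCC2`: 43%

These three were tested in a functional assay on Ehrlich cells (Mus musculus) for cytotoxicity, tested at 25 ug/mL; on this read-out lower numbers stand for a weaker effect and higher numbers for a stronger effect at the one concentration tested. Compound 3 stands second highest of the three numbers: its nearest neighbour is compound 2, lower by a number 13.2 percentage points higher from compound 2 to compound 3 (beyond the scatter), and the furthest is compound 1, higher by a number 17 percentage points lower from compound 1 to compound 3 (beyond the scatter). Both steps lie beyond the scatter.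

Compound 4, `CC1=NNC(=O)/C1=N/Nc1sc2c(c1C(N)=O)CCCC2`, differs from compound 3 in one place: amino in place of ethoxy on a carbonyl carbon. Going by the values given here, no measured pair changes the ethoxy part of the group on that carbonyl carbon. Among the compounds with values here, the step that bears most closely is the one between compound 2 and compound 3, which replaces the whole group on the same aromatic carbon and gives a number 13.2 percentage points higher from compound 2 to compound 3 (beyond the scatter), a modest move. The step from compound 1 to compound 3 touches a different part of the shared core and says nothing about this change. A step of modest size, or none beyond the scatter, is therefore expected in this assay for compound 4, with the direction uncertain. The estimated step from compound 3 is a number 3 percentage points lower from compound 3 to compound 4 (within the scatter). For compound 4 the estimate is 40%, with a range from 25% to 58%.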

Compound 4, a percentage reported as activity, at one concentration (the size of the read-out at that concentration, not a potency): 38.1%
Compound 4: middle estimate off by 1.9 percentage points, on the high side; measured number inside the range.
By their numbers in this assay, from the lowest: compounds 2, 4 and 3 (each within the scatter of the next, the first and the last beyond it); then compound 1.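

In this assay, going by these compounds alone, the ethoxy part of the group on the carbonyl carbon can now be read for the first time: amino in its place gives a number 4.9 percentage points lower from compound 3 to compound 4 (within the scatter), so ethoxycarbonyl and carbamoyl on this aromatic carbon are not told apart. Against cyano, carbamoyl gives a number 8.3 percentage points higher from compound 2 to compound 4 (within the scatter), whereas ethoxycarbonyl gives a number 13.2 percentage points higher from compound 2 to compound 3 (beyond the scatter), so only the ethoxycarbonyl step from cyano clears the scatter, and carbamoyl cannot be separated from either neighbour. No measurement offered here bears on what lies behind these steps.

Open, as far as these compounds go, is whether a carboxylic acid or a longer ester chain such as propoxy on the carbonyl carbon would move the number beyond the scatter from compound 3. Also open, from the compounds shown here alone, is whether amino in place of methyl on the carbon with a double bond to nitrogen would raise the number with carbamoyl present, as compound 1 does with ethoxycarbonyl.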